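The compounds below may be only part of what the source reports. "The series", "measured", "known", "first", "only" and "open" are said of these compounds alone.

Compound 1 `CCCCCCCc1ccc(CCCC(N)(CO)CO)cc1`: > 3 mg/kg
Compound 2 `CCCCCCCc1ccc(CCC(N)(CO)CO)cc1`: 0.1 mg/kg

In a functional assay on the whole organism with Rattus norvegicus as the target (a higher number here means that more compound is needed for the effect, a lower number that less compound is needed), compound 1 reaches only a limit, > 3 mg/kg. Compound 2 gives 0.1 mg/kg, and the step is an at least 30-fold lower number from compound 1 to compound 2 (1.47 log units; beyond the scatter). Compound 2 thus stands as the only number shown; the other value is the limit (the limit of > 3 mg/kg in this assay, at which 1 of the 2 values shown sits). Compound 3 `CCCCCCCCCc1ccc(CCC(N)(CO)CO)cc1` differs from compound 2 by ethyl in place of hydrogen on a saturated chain carbon, seven bonds along the chain from an aromatic carbon. Among the measured compounds shown here, the only measured step concerns the chain on the other side of the core, so no measured step bears on this change. The expected step is no change at the digits printed from compound 2 to compound 3 (within the scatter), none beyond the scatter. Compound 3 is estimated at 0.1 mg/kg, in the range 0.03 mg/kg to 0.4 mg/kg.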

Compound 3, dose for 50% inhibition: 0.03 mg/kg
Beside the measured number, compound 3's estimate is 3.3-fold (0.52 log units) above it, and the stated range covers the measured number.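

In this assay, ethyl in place of hydrogen on a saturated chain carbon, seven bonds along the chain from an aromatic carbon, gives a 3.3-fold lower number from compound 2 to compound 3 (0.52 log units; beyond the scatter). Among the compounds shown here, the only earlier step concerned the chain bearing the amino group, so this is the first sign that the number also responds to a change in the other chain. Nothing measured here accounts for this step.

The compounds shown leave open whether a longer chain would lower the number further, and how an ether oxygen within the chain or a terminal phenyl group would compare.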